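Moving the Halogen on the Phenyl Ring

This account rests on a few compounds, and the source may have more. Where it says the series, first, only, none or still open, it means among the compounds named here.

Of the compounds shown here, three sharing one core have been measured in a functional assay on HepG2 cells (Homo sapiens) for antiproliferative activity, read by MTT assay, with a stated time of 48 h; on this read-out lower numbers stand for stronger inhibition and higher numbers for weaker inhibition. Compound 1 `Cc1ccccc1-n1nncc1CN1C(=O)C2(C(C#N)=C(N)Oc3c(N)cc4nc5ccccc5nc4c32)c2ccccc21` carries a methyl group on its phenyl ring. In this assay compound 1 reaches only the limit > 50000 nM. Compound 2 `CCc1ccccc1-n1nncc1CN1C(=O)C2(C(C#N)=C(N)Oc3c(N)cc4nc5ccccc5nc4c32)c2ccccc21` carries an ethyl group in place of that methyl, and in this assay compound 2 gives 17900 nM, which amounts to an at least 2.7-fold lower number from compound 1 to compound 2 (0.44 log units; beyond the scatter). Compound 3 `N#CC1=C(N)Oc2c(N)cc3nc4ccccc4nc3c2C12C(=O)N(Cc1cnnn1-c1ccccc1Cl)c1ccccc12` carries a chloro group instead, and in this assay compound 3 gives 33500 nM. The step of an at least 1.4-fold lower number from compound 1 to compound 3 (0.17 log units; that floor lies within the scatter) is bounded by a limit (the limit of > 50000 nM in this assay, at which 1 of the 3 values shown sits). The step of a 1.9-fold higher number from compound 2 to compound 3 (0.27 log units; within the scatter) places compound 3 within the scatter of compound 2, so among the numbers shown compound 3 cannot be told apart from compound 2.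

Compound 4 `N#CC1=C(N)Oc2c(N)cc3nc4ccccc4nc3c2C12C(=O)N(Cc1cnnn1-c1cccc(Br)c1)c1ccccc12` differs from compound 3 in one place: 3-bromophenyl in place of 2-chlorophenyl on an aromatic nitrogen. Within the data shown here, no measured step exchanges one whole substituted phenyl for another; the measured steps only replace the group carried on the phenyl, and both steps that reach compound 3 stay within the scatter. The expectation for compound 4 is therefore a step of a 1.1-fold lower number from compound 3 to compound 4 (0.05 log units; within the scatter), not beyond the scatter. Compound 4 is estimated at 30000 nM, expected to lie between 12000 nM and 80000 nM.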

Compound 4, half-maximal inhibitory concentration: > 50000 nM
Compound 4: a limit, no number; the forecaster's own chance of this, stated with the estimate: 25%; at least 1.6-fold (0.22 log units) between middle value and limit.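

In this assay compound 4 returns a limit, not a number, and compound 1 is the other compound at that limit: the limit of > 50000 nM in this assay, at which 2 of the 4 values shown sit.

Replacing a whole substituted phenyl now gives a step that can be told from the scatter: 3-bromophenyl in place of 2-ethylphenyl on the aromatic nitrogen gives an at least 2.7-fold higher number from compound 2 to compound 4 (0.44 log units; beyond the scatter). The same group in place of 2-chlorophenyl gives an at least 1.4-fold higher number from compound 3 to compound 4 (0.17 log units; that floor lies within the scatter), so that exchange may be small or larger, and the step to compound 1 cannot be read, as both ends are limits.

In compound 4 the halogen and its place on the phenyl ring change together, so the compounds shown do not separate the exchange of chlorine for bromine from the move from the 2-position to the 3-position; a 2-bromophenyl or a 3-chlorophenyl group would pull the two apart. Also open, on these data alone, is whether a group of another kind on this phenyl ring, such as an amine or a carboxylic acid, would bring a number rather than a limit.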